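An aryl amide swap in a flat cytotoxicity series

The compounds below may be only part of what the source reports. "The series", "measured", "known", "first", "only" and "open" are said of these compounds alone.

- compound 1 `Cc1ccc(NC(=O)COc2ccc3cc(/C=C4/SC(=O)NC4=O)ccc3c2)cc1` gives 10300 nM
- compound 2 `COc1cccc(NC(=O)COc2ccc3cc(/C=C4/SC(=O)NC4=O)ccc3c2)c1` gives 10400 nM
- compound 3 `Cc1cc(Br)ccc1NC(=O)COc1ccc2cc(/C=C3/SC(=O)NC3=O)ccc2c1` gives 9900 nM

In a functional assay on HeLa cells (Homo sapiens) for cytotoxicity, with a stated time of 20 h (on this read-out higher numbers stand for lower toxicity in this test and lower numbers for higher toxicity in this test), compound 3 stands at 9900 nM and sits level with the other two compounds within the scatter. Compound 4 `O=C(COc1ccc2cc(/C=C3/SC(=O)NC3=O)ccc2c1)Nc1c(F)cc(F)cc1Br` differs from compound 3 in one place (2-bromo-4,6-difluorophenyl in place of 4-bromo-2-methylphenyl on an amide-type nitrogen), with 2-bromo-4,6-difluorophenyl in place of 4-bromo-2-methylphenyl on an amide-type nitrogen.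

Going by the values given here, three measured steps bear on this change, since each replaces the group at that same nitrogen (a 1.0-fold higher number from compound 1 to compound 2 (0.00 log units; within the scatter)) (a 1.0-fold lower number from compound 1 to compound 3 (0.02 log units; within the scatter)) (a 1.1-fold lower number from compound 2 to compound 3 (0.02 log units; within the scatter)). All three lie within the scatter. Compound 3 already carries a bromo group, and the step that introduces it (a 1.0-fold lower number from compound 1 to compound 3 (0.02 log units; within the scatter)) left the number unmoved beyond the scatter. Among the compounds with values here, no measured compound carries fluorine, so that part of the change has not been tested, and the estimate must allow for this with a wider range. No step beyond the scatter is therefore expected in this assay for this swap, and no direction can be favoured. The estimated step is small (a 1.0-fold lower number from compound 3 to compound 4 (0.02 log units; within the scatter)) and is expected to stay within the scatter. For compound 4 the expected value is 9500 nM with an estimated range from 4500 nM to 20000 nM in this read-out.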

Compound 4, half-maximal cytotoxic concentration: 10400 nM
Compound 4: the middle estimate sits 1.1-fold (0.04 log units) below what was measured; the range from low to high includes it.
By their numbers in this assay, from the lowest: compounds 3, 1, 2 and 4 (each within the scatter of the next).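

In this assay, compound 4 is the only compound shown that carries fluorine, and it closes the gap the earlier compounds left: with 2-bromo-4,6-difluorophenyl on the amide-type nitrogen, the number stays level with the rest of the series (a 1.1-fold higher number from compound 3 to compound 4 (0.02 log units; within the scatter)), and the same holds against the two compounds without bromine (no change at the digits printed from compound 2 to compound 4 (within the scatter)) (a 1.0-fold higher number from compound 1 to compound 4 (0.00 log units; within the scatter)). The four aryl groups now shown at this nitrogen, carrying methyl, methoxy, bromo and fluoro groups in different combinations, give no step beyond the scatter, so among these compounds the read-out does not separate one aryl group from another. No measurement shown explains why these numbers stay level.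

Still open, as far as these compounds go, is whether this flatness extends to groups of another kind on that nitrogen, such as a cyclohexyl ring or a longer alkyl chain, or to a phenyl ring bearing an amine or a carboxylic acid. From the compounds shown here alone, all four compounds also share the same core and linking chain, so the part these play in the read-out remains open too.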